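Bromo to Nitro: One Change, Two Cores

The source may hold more compounds than are shown below. What is called first, only, known or untested is meant among the compounds shown, and "the series" means these compounds.

Measured in a functional assay on PANC-1 cells (Homo sapiens) for antiproliferative activity, read by fluorescence and resazurin assay, with a stated time of 48 h; on this read-out lower numbers stand for stronger inhibition and higher numbers for weaker inhibition:
Compound 1, `O=C(N/N=C/c1cc2ccccc2nc1Cl)c1cc2cc(Br)ccc2oc1=O`, gives 5450 nM.
Compound 3, `O=C(N/N=C/c1cccnc1)c1cc2cc(Br)ccc2oc1=O`, gives 8350 nM.
Compound 2, `O=C(N/N=C/c1cccnc1)c1cc2cc([N+](=O)[O-])ccc2oc1=O`, gives 11800 nM.

Compound 3 and compound 2 differ in one place only, (nitro in place of bromo on an aromatic carbon), and that change produced a 1.4-fold higher number from compound 3 to compound 2 (0.15 log units; within the scatter). Compound 1 carries the same bromo-bearing part as compound 3, but the difference between the two cores is not broken down here; the values of the two lie within the scatter of each other.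

Compound 4, `O=C(N/N=C/c1cc2ccccc2nc1Cl)c1cc2cc([N+](=O)[O-])ccc2oc1=O`, has not yet been measured. It differs from compound 1 by nitro in place of bromo on an aromatic carbon, the same change as that between compound 3 and compound 2, at the same place. Because the earlier step was a 1.4-fold higher number from compound 3 to compound 2 (0.15 log units; within the scatter), a step of a 1.3-fold higher number from compound 1 to compound 4 (0.11 log units; within the scatter) is expected in this assay. Compound 4 is therefore estimated at 7000 nM, most likely between 3500 nM and 14000 nM.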

Compound 4, half-maximal inhibitory concentration: 38800 nM
Compound 4: the middle estimate sits 5.5-fold (0.74 log units) below what was measured; measured number above the stated range.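

In this assay, nitro in place of bromo on the core of compound 1 gave a 7.1-fold higher number from compound 1 to compound 4 (0.85 log units; beyond the scatter), so the change did not carry over at one size. The two cores set the change apart by more than the scatter: the same change on two cores in this assay, a 1.4-fold higher number (0.15 log units; within the scatter) from compound 3 to compound 2 and a 7.1-fold higher number (0.85 log units; beyond the scatter) from compound 1 to compound 4, 5.0-fold (0.70 log units) apart, beyond the scatter of two such steps This shows that, in this series, a step read on one core cannot simply be transferred to the other, but with a single pair on each core it does not show which feature of the cores separates the steps, or why.

The compounds shown leave open how an amine or a carboxylic acid on that aromatic carbon would behave on the two cores. They also leave open which of the two steps a third core would resemble.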